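An Undrawn Stereocentre: From Compound 3 to Compound 4

This account rests on a few compounds, and the source may have more. Where it says the series, first, only, none or still open, it means among the compounds named here.

Compound 1 `CC(C)c1cc(-n2nncc2-c2ccc(CN3CCN(c4ccccc4)CC3)cc2)c(O)cc1O` gives 520 nM
Compound 2 `CC(C)c1cc(-n2nncc2-c2ccc(CN3CCCC(O)C3)cc2)c(O)cc1O` gives 45 nM
Compound 3 `CCNC(=O)c1nnn(-c2cc(C(C)C)c(O)cc2O)c1-c1ccc(CN2CCC[C@H](O)C2)cc1` gives 70 nM

In a functional assay on NCI-H460 cells (Homo sapiens) for inhibition, read by sulforhodamine B assay, with a stated time of 72 h (a lower number here means a stronger inhibitor, a higher number a weaker inhibitor), compound 3 (70 nM) lies within the scatter of compound 2 (45 nM). Compound 1 (520 nM) has a higher number than compound 3, and that gap lies beyond the scatter.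

The next compound to be measured is compound 4 `CCNC(=O)c1nnn(-c2cc(C(C)C)c(O)cc2O)c1-c1ccc(CN2CCCC(O)C2)cc1`, and it departs from compound 3 in one respect only: the two compounds have the same atoms and bonds; at least one stereo element is drawn with a configuration in one of them and without one in the other: 1 of 1 stereo elements differ; a stereocentre at a saturated ring carbon is drawn S in compound 3 and without a configuration in compound 4 (a stereocentre at a saturated ring carbon is drawn S in compound 3 and without a configuration in compound 4). The two compounds have the same atoms and bonds. For the measured compounds named here, the measured set holds no pair that differs in this way alone, so the size of such a step cannot be read from it.

In this assay no step beyond the scatter is expected, and neither direction is favoured. This expectation starts from compound 3 at 70 nM and rests on the unchanged atoms and bonds. The expected no change at the digits printed from compound 3 to compound 4 (within the scatter) is small. Compound 4 is estimated at 70 nM (expected range 35 nM to 140 nM).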

Compound 4, half-maximal inhibitory concentration: 62 nM
Compound 4: middle estimate off by 1.1-fold (0.05 log units), on the high side, within the range that was stated.
By their numbers in this assay, from the lowest: compounds 2, 4 and 3 (each within the scatter of the next); then compound 1.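

In this assay, the first pair differing only in how a stereocentre is drawn gives a 1.1-fold lower number from compound 3 to compound 4 (0.05 log units; within the scatter), so drawing the saturated ring carbon as S or leaving it without a configuration makes no difference that this read-out can separate. For the compounds shown here, the second step, a 1.4-fold higher number from compound 2 to compound 4 (0.14 log units; within the scatter), is the first single-place reading of ethylcarbamoyl in place of hydrogen on an aromatic carbon, and it shows that this substituent can be carried without a step beyond the scatter when the ring carbon is drawn without a configuration, which compounds 1, 2 and 3 alone could not show, as none of them formed such a pair. The stereochemical reading has a clear limit, and what it rests on is this: the fact that one of compounds 3 and 4 is drawn with a defined configuration and the other without, at the place where they differ.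

The compounds shown do not say how a compound drawn with the opposite configuration at that ring carbon would read, so the role of the configuration itself stays open. Nor do they say whether the same tolerance holds for a carboxylic acid or a longer chain in place of ethylcarbamoyl, or for an amine in place of the hydroxyl on the saturated ring.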